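A few compounds are considered here, and "the series" means these few. Any claim that something is new, unique, unknown or untested is made for them only; others in the source may bear on it.

Compound 3 `CNc1cc(-c2c(C)nn(-c3nc(-c4ccc(Cl)c(Cl)c4)c(SC(C)C)s3)c2C(=O)O)ccn1` gives 18000 nM in a functional assay on BJAB cells (Homo sapiens) for antiproliferative activity, with a stated time of 4 days (a lower number here means that less compound is needed, a higher number that more compound is needed for the effect), the highest of the three numbers: compound 1 `Cc1ccc(-c2c(C)nn(-c3nc(-c4ccc(Cl)c(Cl)c4)c(SC(C)C)s3)c2C(=O)O)cc1` gives 3800 nM and compound 2 `Cc1nn(-c2nc(-c3ccc(Cl)c(Cl)c3)c(SC(C)C)s2)c(C(=O)O)c1-c1cnn(C)c1` gives 6800 nM. Both steps run toward compound 3: a 4.7-fold higher number from compound 1 to compound 3 (0.68 log units; beyond the scatter) and a 2.6-fold higher number from compound 2 to compound 3 (0.42 log units; beyond the scatter). Compound 4 `COc1cccc(-c2c(C)nn(-c3nc(-c4ccc(Cl)c(Cl)c4)c(SC(C)C)s3)c2C(=O)O)c1` carries 3-methoxyphenyl in place of 2-(methylamino)pyridin-4-yl on an aromatic carbon. Among the measured compounds shown here, no measured pair shows this exact exchange, but it returns a six-membered ring of carbon only, the reverse sense of a 4.7-fold higher number from compound 1 to compound 3 (0.68 log units; beyond the scatter), so a lower number than compound 3 is expected, of roughly that size; the methoxy group differs from the methyl of compound 1, so the range is kept wide. Compound 4 is expected to give 5000 nM, range 2000 nM to 14000 nM, an estimated step of a 3.6-fold lower number from compound 3 to compound 4 (0.56 log units; beyond the scatter).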

Compound 4, half-maximal effective concentration: 14000 nM
For compound 4 the middle estimate is 2.8-fold (0.45 log units) below the measured one, and the stated range covers the measured number.
By their numbers in this assay, from the lowest: compounds 1 and 2 (each within the scatter of the next); then compounds 4 and 3 (each within the scatter of the next).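

In this assay, 3-methoxyphenyl in place of 2-(methylamino)pyridin-4-yl gives a 1.3-fold lower number from compound 3 to compound 4 (0.11 log units; within the scatter), so a six-membered ring of carbon only does not by itself recover the number of compound 1, as a 3.7-fold higher number from compound 1 to compound 4 (0.57 log units; beyond the scatter) shows. With a 2.1-fold higher number from compound 2 to compound 4 (0.31 log units; beyond the scatter), 1-methyl-1H-pyrazol-4-yl also stays apart from 3-methoxyphenyl, and ring type alone does not order these four compounds. No supporting data on the compounds bear on this result. Open, from the compounds shown here alone, is whether the methoxy group or its ring position separates compound 4 from compound 1; 3-methylphenyl and 4-methoxyphenyl would distinguish these.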